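The source may report more compounds than this note shows. Statements on the series, on what has been measured and on what is new or still open speak of the compounds shown alone.

In a functional assay on KYSE-450 cells (Homo sapiens) for inhibition, read by MTT assay, with a stated time of 48 h (on this read-out lower numbers stand for stronger inhibition and higher numbers for weaker inhibition), compound 1 `CCCCC(=O)N(Cc1ccc(OC)c(O)c1)c1cc(OC)c(OC)c(OC)c1` gives 300 nM. This is the lower of the two actual numbers in this small set, since compound 3 `C/C=C/C(=O)N(Cc1cc(OC)c(OC)c(OC)c1)c1ccc(OC)c(O)c1` gives 9160 nM, a gap well beyond the usual scatter. For compound 2 `COc1cc(NCc2ccc(Cl)cc2)cc(OC)c1OC`, this assay reports only a limit, > 80000 nM.

Compound 4 `C#CC(=O)N(Cc1ccc(OC)c(O)c1)c1cc(OC)c(OC)c(OC)c1` has not yet been measured. It keeps the core of compound 1 but carries ethynyl in place of butyl on a carbonyl carbon. Going by the values given here, no measured pair shows this change on its own, so any expectation rests on thin ground. The closest guide is compound 3, another amide, at 9160 nM, though it differs from compound 1 in more than one place. A moderate rise in the number, meaning weaker inhibition, is therefore expected, and the estimated change is a 5.0-fold higher number from compound 1 to compound 4 (0.70 log units; beyond the scatter). Compound 4 is expected to give about 1500 nM, with an estimated range from 200 nM to 12000 nM.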

Compound 4, half-maximal inhibitory concentration: 570 nM
Beside the measured number, compound 4's estimate is 2.6-fold (0.42 log units) above it; measured number inside the range.
By their numbers in this assay, from the lowest: compounds 1 and 4 (each within the scatter of the next); then compound 3. At a limit, above all of these: compound 2.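

In this assay, putting ethynyl in place of butyl on a carbonyl carbon gives a 1.9-fold higher number from compound 1 to compound 4 (0.28 log units; within the scatter), so the two groups cannot be told apart at this place. Going by these compounds alone, this is the first comparison in the set in which only one place differs, and it shows that the butyl chain can be swapped for a smaller group holding a triple bond with no change beyond the scatter. Nothing among the data shown explains why these two groups read alike.

Going by these compounds, with a single pair speaking for this position, it remains open how a longer chain such as hexyl, a phenyl ring or a chain ending in an amine would read on the same carbonyl carbon. On these data alone, whether the match between butyl and ethynyl also holds in other cell lines is equally open.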